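Chlorine position on the benzyl ester in the shared series

The compounds below may be only part of what the source reports. "The series", "measured", "known", "first", "only" and "open" are said of these compounds alone.

Compound 3 `CC#CCn1c(N2CCC[C@@H](N)C2)nc2c1c(=O)n(Cc1ccc(Cl)cc1C(=O)OC)c(=O)n2C` gives in an ADME assay on isolated protein for inhibition of Dipeptidyl peptidase 9 (Homo sapiens), with stated times of 15 min, 60 s and 20 min (a higher number here means a weaker inhibitor, a lower number a stronger inhibitor), only a limit of the assay, > 100000 nM. Compound 1 `CC#CCn1c(N2CCC[C@@H](N)C2)nc2c1c(=O)n(Cc1ccc(Cl)cc1C(=O)OCC)c(=O)n2C` likewise shows only a limit, > 100000 nM. Compound 2 `CC#CCn1c(N2CCC[C@@H](N)C2)nc2c1c(=O)n(Cc1c(OC)cccc1C(=O)O)c(=O)n2C` also sits at a limit, > 100000 nM. The steps a step that the two limits leave unreadable from compound 1 to compound 3 and a step that the two limits leave unreadable from compound 2 to compound 3 are unreadable for that reason, as is a step that the two limits leave unreadable from compound 1 to compound 2, and the limit of > 100000 nM in this assay, at which 3 of the 3 values shown sit, is all the series offers. Compound 4 `CC#CCn1c(N2CCC[C@@H](N)C2)nc2c1c(=O)n(Cc1cc(Cl)ccc1C(=O)OC)c(=O)n2C` differs from compound 3 by 5-chloro-2-(methoxycarbonyl)phenyl in place of 4-chloro-2-(methoxycarbonyl)phenyl on a saturated chain carbon bound to an aromatic nitrogen. Among the compounds with values here, no measured step reads this change, and with every value at the limit nothing points to any direction. The step expected in this assay is a step that the limit leaves unreadable from compound 3 to compound 4, nothing beyond the scatter, with a limit again likely. Compound 4 is estimated at 150000 nM, within 60000 nM to 400000 nM.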

Compound 4, half-maximal inhibitory concentration: > 100000 nM
Compound 4 was reported as a limit (the forecaster's own chance of this, stated with the estimate: 85%); the middle value is on the limit's open side.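

No step from compound 4 to compound 1, compound 2 or compound 3 can be read in this assay, where each value is a limit: the limit of > 100000 nM in this assay, at which 4 of the 4 values shown sit.

The compounds shown leave open whether 5-chloro-2-(methoxycarbonyl)phenyl and 4-chloro-2-(methoxycarbonyl)phenyl differ in inhibition at all.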